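The source may report more compounds than this note shows. Statements on the series, on what has been measured and on what is new or still open speak of the compounds shown alone.

Compound 1 `COC(=O)c1scc(-c2ccc(NC(=O)c3ccccn3)cc2)c1OC` gives 19200 nM
Compound 2 `COC(=O)c1scc(-c2ccc(NC(=O)c3ccc(F)c(Cl)n3)cc2)c1OC` gives 10300 nM
Compound 3 `COC(=O)c1scc(-c2ccc(NC(=O)c3cccc(I)c3)cc2)c1OC` gives 12300 nM

These three values come from a functional assay on MCF7 cells (Homo sapiens) for antiproliferative activity, read by MTT assay, with a stated time of 24 h (on this read-out lower numbers stand for stronger inhibition and higher numbers for weaker inhibition), and the compounds differ only in the group on a carbonyl carbon. Compound 3 cannot be separated from the other two. The comparisons show a 1.6-fold lower number from compound 1 to compound 3 (0.19 log units; within the scatter) and a 1.2-fold higher number from compound 2 to compound 3 (0.08 log units; within the scatter), so its place among the three carries no weight.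

Compound 4 `COC(=O)c1scc(-c2ccc(NC(=O)c3cc(I)ccc3F)cc2)c1OC` keeps the rest of compound 3 and turns 3-iodophenyl into 2-fluoro-5-iodophenyl. This puts fluoro in place of hydrogen on an aromatic carbon, ortho to a large group and para to an iodo group (fluoro in place of hydrogen on an aromatic carbon).

Going by the values given here, no measured step makes this exact change. The nearest comparison also brings in a fluoro, but together with a chloro, as 6-chloro-5-fluoropyridin-2-yl replaces pyridin-2-yl. It shows a 1.9-fold lower number from compound 1 to compound 2 (0.27 log units; within the scatter). Even that larger exchange stays within the scatter, as does the swap of the whole group in a 1.6-fold lower number from compound 1 to compound 3 (0.19 log units; within the scatter). In this assay, the single fluoro is therefore expected to produce no step beyond the scatter, and neither direction is favoured.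

Compound 4 is expected near 12000 nM, with an estimated range from 6000 nM to 24000 nM. The expected result is a 1.0-fold lower number from compound 3 to compound 4 (0.01 log units; within the scatter).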

Compound 4, half-maximal inhibitory concentration: 22500 nM
Compound 4: middle estimate off by 1.9-fold (0.27 log units), on the low side, within the range that was stated.
By their numbers in this assay, from the lowest: compounds 2, 3, 1 and 4 (each within the scatter of the next, the first and the last beyond it).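

In this assay, placing fluoro on an aromatic carbon, ortho to a large group and para to an iodo group, gives a 1.8-fold higher number from compound 3 to compound 4 (0.26 log units; within the scatter), so this single added atom does not clearly separate the two compounds. Comparing the whole 2-fluoro-5-iodophenyl group with the other groups on the carbonyl carbon gives a 1.2-fold higher number from compound 1 to compound 4 (0.07 log units; within the scatter), which also stays inside the scatter, and a 2.2-fold higher number from compound 2 to compound 4 (0.34 log units; beyond the scatter), a modest step that passes beyond it. Going by these compounds alone, this makes 2-fluoro-5-iodophenyl and 6-chloro-5-fluoropyridin-2-yl the only pair of groups here that the assay can tell apart, even though each of the two remains within the scatter of both pyridin-2-yl and 3-iodophenyl.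

No measurement is available that would account for this difference between the two groups. As far as these compounds go, it remains open whether a different group in place of the fluoro at this position, such as a methoxy, an amine or a carboxylic acid, would move the number beyond the scatter from compound 3, and in which direction.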